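The source may report more compounds than this note shows. Statements on the series, on what has been measured and on what is new or still open speak of the compounds shown alone.

Three measured compounds share one core and differ only in the group on the chain: compound 1 `Nc1ncn(CCC2(N)OC(=O)C(OCc3ccccc3)=C2OCc2ccccc2)c(=O)n1`, compound 2 `NC1(CCn2ncc(=O)[nH]c2=O)OC(=O)C(OCc2ccccc2)=C1OCc1ccccc1` and compound 3 `Nc1ccn(CCC2(N)OC(=O)C(OCc3ccccc3)=C2OCc2ccccc2)c(=O)n1`. In a functional assay on MCF7 cells (Homo sapiens) for inhibition, read by MTT assay, with a stated time of 72 h (a higher number here means a weaker inhibitor, a lower number a stronger inhibitor), compound 3 gives 32000 nM. For compound 1 the reading in this assay is a limit, > 100000 nM. For compound 2 the reading is likewise a limit, > 100000 nM. Among the measured compounds shown here, compound 3 therefore stands as the only number in the set, with the two other readings at the limit of > 100000 nM in this assay, at which 2 of the 3 values shown sit. The steps into compound 3 read as an at least 3.1-fold lower number from compound 1 to compound 3 (0.49 log units; beyond the scatter) and an at least 3.1-fold lower number from compound 2 to compound 3 (0.49 log units; beyond the scatter), while a step that the two limits leave unreadable from compound 1 to compound 2.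

Compound 4 `Cc1cn(CCC2(N)OC(=O)C(OCc3ccccc3)=C2OCc2ccccc2)c(=O)[nH]c1=O` is the next member: a group of 9 heavy atoms (5 carbon, 2 nitrogen, 2 oxygen; one six-membered aromatic ring with 2 hetero atoms) in place of a group of 8 heavy atoms (4 carbon, 3 nitrogen, 1 oxygen; one six-membered aromatic ring with 2 hetero atoms), on a saturated chain carbon, two bonds along the chain from a saturated ring carbon. For the measured compounds named here, both measured steps into compound 3 run the same way and are at least modest, yet neither exchanges the group of compound 3 for the one in compound 4, so no measured step bears directly on this change and its direction is open. A number near compound 3 and a return to the limit are both plausible outcomes. Compound 4 is expected to give 50000 nM, in the range 15000 nM to 200000 nM. The estimate means a step of a 1.6-fold higher number from compound 3 to compound 4 (0.19 log units; within the scatter), expected with wide uncertainty.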

Compound 4, half-maximal inhibitory concentration: 80400 nM
The estimate for compound 4 lay 1.6-fold (0.21 log units) below the measured number; the measured number falls inside the stated range.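

In this assay, among the compounds shown here, a 2.5-fold higher number from compound 3 to compound 4 (0.40 log units; beyond the scatter) is the only readable exchange between two groups that each carry a six-membered aromatic ring with 2 hetero atoms, and it shows that the number at this saturated chain carbon shifts even when the ring type is kept, with the group of 8 heavy atoms in compound 3 giving the lower number. Compound 4 still gives a measured number, whereas compound 1 and compound 2, whose rings have 3 hetero atoms, each give only an assay limit: the limit of > 100000 nM in this assay, at which 2 of the 4 values shown sit. The steps of an at least 1.2-fold lower number from compound 2 to compound 4 (0.09 log units; that floor lies within the scatter) and an at least 1.2-fold lower number from compound 1 to compound 4 (0.09 log units; that floor lies within the scatter) have floors that lie within the scatter, so they establish no firm order between compound 4 and either compound 1 or compound 2.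

The compounds shown do not separate the two differences within the 3>4 exchange, the extra carbon on the ring and the swap of a ring nitrogen-bearing group for an oxygen-bearing one, so neither can be tied to the step alone. Going by these compounds, it also remains open whether the gap between these two groups would persist on a longer chain, or whether an amine or a carboxylic acid on the ring would move the number at all.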